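Dropping the ring methyl: from compound 1 to compound 3

The source may hold more compounds than are shown below. What is called first, only, known or untested is meant among the compounds shown, and "the series" means these compounds.

Compound 1 `C[C@@]1(O)CC(=O)OC(CSc2nc(-c3ccccc3)c(-c3ccccc3)[nH]2)C1` gives 170 nM in an assay on microsomes from liver for inhibition of sterol O-acyltransferase 1 (Rattus norvegicus); on this read-out higher numbers stand for weaker inhibition and lower numbers for stronger inhibition. Compound 2 `CC(C)c1ccc(-c2nc(SC[C@H]3C[C@@](C)(O)CC(=O)O3)[nH]c2-c2ccc(C(C)C)cc2)cc1.CC(C)c1ccc(-c2nc(SC[C@H]3C[C@](C)(O)CC(=O)O3)[nH]c2-c2ccc(C(C)C)cc2)cc1` gives 230 nM in this assay, a number within the scatter of that of compound 1, so the two cannot be told apart. Compound 3 `O=C1CC(O)CC(CSc2nc(-c3ccccc3)c(-c3ccccc3)[nH]2)O1` differs from compound 1 by a group of 8 heavy atoms (5 carbon, 3 oxygen; one six-membered non-aromatic ring with 1 hetero atom) in place of a group of 9 heavy atoms (6 carbon, 3 oxygen; one six-membered non-aromatic ring with 1 hetero atom), on a saturated chain carbon bound to a sulfur. Going by the values given here, no measured pair shows the effect of such a change. The removal of one carbon from the ring is small, so the expected step from compound 1 to compound 3, a 1.2-fold higher number from compound 1 to compound 3 (0.07 log units; within the scatter), is not beyond the scatter. Compound 3 is therefore estimated at 200 nM, with a range from 80 nM to 500 nM.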

Compound 3, half-maximal inhibitory concentration: 910 nM
For compound 3 the middle estimate is 4.6-fold (0.66 log units) below the measured one; the whole stated range lies below it.
By their numbers in this assay, from the lowest: compounds 1 and 2 (each within the scatter of the next); then compound 3.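

Removing one carbon from the ring of the group on the saturated chain carbon bound to a sulfur gives a 5.4-fold higher number from compound 1 to compound 3 (0.73 log units; beyond the scatter) in this assay, so inhibition is weaker. This position therefore responds to a very small change, and the ring methyl of compound 1 matters on this read-out. Nothing measured here gives a reason for this step.

On these data alone, it remains open whether a longer chain, such as an ethyl group, could take the place of that methyl. As far as these compounds go, the effect of the same change on other cores also remains unknown.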